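Swapping a chlorothiophene for a pyridine on a shared core

The source may hold more compounds than are shown below. What is called first, only, known or untested is meant among the compounds shown, and "the series" means these compounds.

Of the compounds shown here, three built on a shared core have been measured in an assay on isolated protein for inhibition of coagulation factor X (Oryctolagus cuniculus), tested at 1 uM; on this read-out higher numbers stand for more inhibition at the one concentration tested (going by the name of the read-out) and lower numbers for less inhibition. Compound 1 `O=C1[C@@H](NS(=O)(=O)c2ccc(-c3ccccn3)s2)CCN1Cc1cc2[nH]cccc-2n1` gives 8%. Compound 2 `O=C1[C@@H](NS(=O)(=O)c2ccc(-c3ccc(Cl)s3)s2)CCN1Cc1cc2[nH]cccc-2n1` gives 42%, the top number of the three, although compound 3 `Cc1c(S(=O)(=O)N[C@H]2CCN(Cc3cc4[nH]cccc-4n3)C2=O)sc2ccc(Cl)cc12` gives 40%, a number within the usual scatter of it, so the two cannot be told apart. Compound 1 sits well below both.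

Among the compounds with values here, the only single-point step among the measured compounds is a number 34 percentage points higher from compound 1 to compound 2 (beyond the scatter). It shows that replacing a pyridine ring with a chlorinated thiophene at that spot raised inhibition by a large amount.

Compound 4 `O=C1[C@@H](NS(=O)(=O)c2ccc(-c3ccncc3)s2)CCN1Cc1cc2[nH]cccc-2n1` is not yet measured. Relative to compound 2 it carries pyridin-4-yl in place of 5-chlorothiophen-2-yl on an aromatic carbon. This is close to the reverse of the step from compound 1 to compound 2: a pyridine again replaces the chlorinated thiophene, though the ring is now joined through a different carbon. Within the data shown here, no measured pair tells how much that attachment matters, so the earlier step is the only guide. A drop of roughly its size is therefore expected, giving a number 32 percentage points lower from compound 2 to compound 4 (beyond the scatter) for this assay. Compound 4 is estimated at 10%, with a range from 0% to 25%.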

Compound 4, a percentage reported as inhibition, at one concentration (the size of the read-out at that concentration, not a potency): 35%
Compound 4: the middle estimate sits 25 percentage points below what was measured; measured number outside the range, above it.
By their numbers in this assay, from the lowest: compound 1; then compounds 4, 3 and 2 (each within the scatter of the next).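

In this assay, the swap at this position gives a number 7 percentage points lower from compound 2 to compound 4 (within the scatter) and so leaves compound 2 and compound 4 indistinguishable, which means that a pyridine ring at this spot does not by itself go with the low number of compound 1. The attachment of the pyridine matters instead, since pyridin-4-yl in place of pyridin-2-yl gives a number 27 percentage points higher from compound 1 to compound 4 (beyond the scatter) in the same read-out, although the two groups have the same atoms and differ only in how the ring is joined to the core. Among these three groups, then, the low number belongs to pyridin-2-yl rather than to pyridines in general, and the sulfur and chlorine of 5-chlorothiophen-2-yl are not required to reach the level of compound 2.

Nothing available explains why the two pyridine attachments read so differently and the single test concentration gives no potency for any of these compounds. On these data alone, how pyridin-3-yl, a plain phenyl ring or a phenyl ring carrying an aminomethyl group would read at this same position also remains open.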